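Swapping the Amide Aryl Group: Expected Cytotoxicity of Compound 4

This account rests on a few compounds, and the source may have more. Where it says the series, first, only, none or still open, it means among the compounds named here.

Compound 1 `O=C(CSc1nncnc1-c1cccc2ccccc12)Nc1ccc([N+](=O)[O-])cc1Cl` was tested in an ADME assay on MT4 cells (Homo sapiens) for cytotoxicity, read by MTT assay (on this read-out lower numbers stand for higher toxicity in this test and higher numbers for lower toxicity in this test), where compound 1 gives 150000 nM. Compound 3 `CCOC(=O)c1ccc(NC(=O)CSc2nncnc2-c2cccc3ccccc23)c(Cl)c1` gives 150000 nM in this assay, and compound 2 `O=C(CSc1nncnc1-c1ccccc1Cl)Nc1ccccc1Cl` gives 90000 nM; all three numbers lie within the usual scatter of one another. Within the data shown here, the only single-point step measured, no change at the digits printed from compound 1 to compound 3 (within the scatter), shows that exchanging the group on the aromatic carbon left the read-out unchanged.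

Compound 4 `O=C(CSc1nncnc1-c1cccc2ccccc12)Nc1ccccc1F` differs from compound 1 in one place: 2-fluorophenyl in place of 2-chloro-4-nitrophenyl on an amide-type nitrogen. Among the measured compounds shown here, no measured step alters this part of the molecule, so the expectation rests on the flat picture across compounds 1, 2 and 3. Compound 4 is therefore expected to show no step beyond the scatter, a 1.2-fold lower number from compound 1 to compound 4 (0.06 log units; within the scatter), with an estimated value of 130000 nM and a range from 60000 nM to 250000 nM.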

Compound 4, half-maximal cytotoxic concentration: 65000 nM
Compound 4: the middle estimate sits 2.0-fold (0.30 log units) above what was measured; the range from low to high includes it.
By their numbers in this assay, from the lowest: compounds 4, 2, 1 and 3 (each within the scatter of the next, the first and the last beyond it).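

Changing the group on the amide-type nitrogen moves the read-out beyond the scatter: swapping 2-chloro-4-nitrophenyl for 2-fluorophenyl gives a 2.3-fold lower number from compound 1 to compound 4 (0.36 log units; beyond the scatter) in this assay, a modest move towards higher toxicity in this test. The swap removes the chlorine and the nitro group and adds a fluorine in one step, so the compounds cannot assign the step to any one of these. Nothing measured here explains the step. Still open, from the compounds shown here alone, is how a plain phenyl, or a phenyl carrying an amine or a carboxylic acid, would read on the core of compound 1.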